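The source may report more compounds than this note shows. Statements on the series, on what has been measured and on what is new or still open speak of the compounds shown alone.

Working notes on the series. Three compounds share one core. Compound 1 `Cn1ncc2c(=O)n(-c3ccccc3)c(SC(C)(C)c3ccccc3)nc21` gives in an assay on isolated protein for inhibition of aldehyde dehydrogenase 1A1 (Homo sapiens) (a lower number here means a stronger inhibitor, a higher number a weaker inhibitor), a value of 1900 nM. Compound 2 `CCC(Sc1nc2c(cnn2C)c(=O)n1-c1ccccc1)c1ccccc1` gives 150 nM in this assay, and the change from compound 1 to compound 2 brought a step of a 13-fold lower number from compound 1 to compound 2 (1.10 log units; beyond the scatter). Compound 3 `COc1cccc(C(C)Sc2nc3c(cnn3C)c(=O)n2-c2ccccc2)c1` gives 451 nM in this assay, which places it second highest of the three numbers, beyond the scatter from compound 2 on one side and from compound 1 on the other.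

Compound 4 `CC(Sc1nc2c(cnn2C)c(=O)n1-c1ccccc1)c1cccc(F)c1` is not yet measured. It differs from compound 3 by fluoro in place of methoxy on an aromatic carbon. The only single-point step shown, from compound 1 to compound 2, concerns the substituent on sulfur, not the aromatic ring, so it does not bear directly on this change. There is no shown step that does. The expectation for this assay is therefore a step within or near the scatter, a 1.3-fold lower number from compound 3 to compound 4 (0.11 log units; within the scatter), without a firm direction. Compound 4 is estimated at 350 nM, with a range from 120 nM to 1000 nM.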

Compound 4, half-maximal inhibitory concentration: 151 nM
Beside the measured number, compound 4's estimate is 2.3-fold (0.37 log units) above it; the range from low to high includes it.
By their numbers in this assay, from the lowest: compounds 2 and 4 (each within the scatter of the next); then compound 3; then compound 1.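

In this assay the aromatic carbon carrying methoxy in compound 3 proves sensitive to its substituent: the first change shown on this ring gives a 3.0-fold lower number from compound 3 to compound 4 (0.48 log units; beyond the scatter) with fluoro in place of methoxy. The sulfur substituent 1-(3-fluorophenyl)ethyl gives a 13-fold lower number from compound 1 to compound 4 (1.10 log units; beyond the scatter) when it stands in place of 1-methyl-1-phenylethyl, and a 1.0-fold higher number from compound 2 to compound 4 (0.00 log units; within the scatter) against 1-phenylpropyl, so these two sulfur substituents cannot be told apart in this measurement. No available evidence bears on why the fluoro for methoxy change moves the number.

It remains open whether methoxy lowers the value's standing or fluoro improves it, since 1-phenylethyl with a plain hydrogen at this carbon is absent from the compounds shown. Also open, on these data alone, is how an amine, a carboxylic acid or a chloro group on the same aromatic carbon would read.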